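The compounds below may be only part of what the source reports. "The series", "measured", "known", "first", "only" and "open" are said of these compounds alone.

Compound 1 `c1ccc2c(-c3cn4ccnc4c(-c4ccc5ncn(C6CCCCC6)c5c4)n3)cccc2c1`: 44.7%
Compound 2 `Fc1ccc(-c2cn3ccnc3c(-c3ccc4ncn(C5CCCCC5)c4c3)n2)cc1`: 25.2%
Compound 3 `COc1ccccc1-c1cn2ccnc2c(-c2ccc3ncn(C4CCCCC4)c3c2)n1`: 22.4%

All three compounds share one core and differ only in the aromatic group attached to it, and all were tested in a functional assay on MOLT-4 cells (Homo sapiens) for inhibition, read by sulforhodamine B assay, with a stated time of 48 h, tested at 10 uM; a lower number here means less inhibition, a higher number more inhibition at the concentration tested (going by the name of the read-out). Compound 3 has the lowest of the three numbers, but its gap to compound 2, a number 2.8 percentage points lower from compound 2 to compound 3 (within the scatter), is within the scatter, so the two cannot be told apart; only compound 1 stands clearly higher, as a number 22.3 percentage points lower from compound 1 to compound 3 (beyond the scatter) shows.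

Compound 4 `FC(F)(F)c1cccc(-c2cn3ccnc3c(-c3ccc4ncn(C5CCCCC5)c4c3)n2)c1` carries 3-(trifluoromethyl)phenyl in place of 2-methoxyphenyl on an aromatic carbon. Going by the values given here, two measured steps bear on this. The drops a number 19.5 percentage points lower from compound 1 to compound 2 (beyond the scatter) and a number 22.3 percentage points lower from compound 1 to compound 3 (beyond the scatter) both replaced the two-ring naphthalen-1-yl by a single-ring substituted phenyl. Among the compounds with values here, the one step that swapped one substituted phenyl for another, a number 2.8 percentage points lower from compound 2 to compound 3 (within the scatter), stayed within the scatter. The change to compound 4 is again a phenyl-for-phenyl swap, so the expected step is a number 3.6 percentage points higher from compound 3 to compound 4 (within the scatter), not beyond the scatter. Compound 4 is therefore estimated at 26%, in a range from 10% to 45%.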

Compound 4, a percentage reported as inhibition, at one concentration (the size of the read-out at that concentration, not a potency): 32.9%
Estimate against measurement, compound 4: 6.9 percentage points below, and the stated range covers the measured number.
By their numbers in this assay, from the lowest: compounds 3, 2 and 4 (each within the scatter of the next, the first and the last beyond it); then compound 1.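

In this assay, a swap of one substituted phenyl for another can now move the number: 3-(trifluoromethyl)phenyl in place of 2-methoxyphenyl gives a number 10.5 percentage points higher from compound 3 to compound 4 (beyond the scatter). The same group in place of 4-fluorophenyl gives only a number 7.7 percentage points higher from compound 2 to compound 4 (within the scatter), so the single-ring compounds do not fall into cleanly separate levels, and the naphthalen-1-yl group still stands clearly higher, with a number 11.8 percentage points lower from compound 1 to compound 4 (beyond the scatter). Nothing available here explains why these groups differ.

The compounds shown leave open whether the trifluoromethyl group itself or its place on the phenyl ring matters. They also leave open how a phenyl ring carrying an amine or a carboxylic acid, or a piperidine ring in place of the phenyl, would read at this position.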